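The source may report more compounds than this note shows. Statements on the series, on what has been measured and on what is new or still open speak of the compounds shown alone.

Compound 1 `COc1ccc(-c2ccc(COC3CN(C#N)C3)cc2)cc1` and compound 2 `N#CN1CC(OCc2ccc(-c3ccc(C(F)(F)F)cc3)cc2)C1` share one core. In an assay on isolated protein for inhibition of N-acylethanolamine-hydrolyzing acid amidase (Homo sapiens), read by fluorescence, with a stated time of 90 min (a lower number here means a stronger inhibitor, a higher number a weaker inhibitor), compound 1 gives 0.94 nM, and compound 2 gives 1.6 nM. The change between them is methoxy in place of trifluoromethyl on an aromatic carbon, and it made a 1.7-fold lower number from compound 2 to compound 1 (0.23 log units; within the scatter). Compound 3 `COc1cccc(-c2ccc(COC3CN(C#N)C3)c(C(F)(F)F)c2)c1` is built on a different core; how that core differs from the core of compound 2 is not broken down here. In this assay compound 3 gives 0.85 nM, a number close to those of compound 1 and compound 2. Compound 4 `COc1cccc(-c2ccc(COC3CN(C#N)C3)c(OC)c2)c1` has not yet been measured. It differs from compound 3 by methoxy in place of trifluoromethyl on an aromatic carbon. Among the compounds with values here, this is the same kind of change as the one from compound 2 to compound 1, not the same one: there the place was para to a large group, here it is ortho to a ((1-cyanoazetidin-3-yl)oxy)methyl group and meta to a 3-methoxyphenyl group. For compound 4 the expected step is a 1.1-fold lower number from compound 3 to compound 4 (0.03 log units; within the scatter), because the earlier step of a 1.7-fold lower number from compound 2 to compound 1 (0.23 log units; within the scatter) lay within the scatter. For compound 4 in this assay the estimate is 0.8 nM, with a range from 0.4 nM to 1.6 nM.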

Compound 4, half-maximal inhibitory concentration: 2.8 nM
The estimate for compound 4 lay 3.5-fold (0.54 log units) below the measured number, and the stated range ends below it.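

In this assay the replacement of trifluoromethyl by methoxy, here on an aromatic carbon ortho to a ((1-cyanoazetidin-3-yl)oxy)methyl group and meta to a 3-methoxyphenyl group, gave a 3.3-fold higher number from compound 3 to compound 4 (0.52 log units; beyond the scatter). The step measured on one core did not carry over to the other: the same change on two cores in this assay, a 1.7-fold lower number (0.23 log units; within the scatter) from compound 2 to compound 1 and a 3.3-fold higher number (0.52 log units; beyond the scatter) from compound 3 to compound 4, 5.6-fold (0.75 log units) apart, beyond the scatter of two such steps. Within the data shown here, with only one pair on each core, and with the change sitting in a different place in each pair, the data do not separate an effect of the core from an effect of the place, and they do not show why the steps differ.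

The compounds shown leave open whether the same replacement at this place gives a step of similar size on other cores, or with a different group in place of the 3-methoxyphenyl group. Also open, on these data alone, is how an amine, a hydroxyl or a chlorine at this place would read in this assay.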